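Swapping fluoro for chloro on the benzyl group

The source may report more compounds than this note shows. Statements on the series, on what has been measured and on what is new or still open speak of the compounds shown alone.

Measured in a functional assay on A2780 cells (Homo sapiens) for inhibition, read by MTT assay, with a stated time of 72 h; a lower number here means a stronger inhibitor, a higher number a weaker inhibitor
- compound 1 `O=C1/C(=C\c2ccccc2)c2c(ncn2COCc2ccccc2)CCN1Cc1ccc(F)cc1` gives 24800 nM
- compound 2 `O=C1/C(=C\c2ccccc2)c2c(ncn2COCc2ccccc2)CCN1Cc1ccc(-c2ccccc2)cc1` gives 48300 nM

In this assay compound 1 has a single measured neighbour, and the two cannot be ranked. The step between them is a 1.9-fold higher number from compound 1 to compound 2 (0.29 log units; within the scatter). Compound 3 `O=C1/C(=C\c2ccccc2)c2c(ncn2COCc2ccccc2)CCN1Cc1ccc(Cl)cc1` has not been measured and differs from compound 1 by chloro in place of fluoro on an aromatic carbon. That one measured step also replaces the fluoro on an aromatic carbon, and it stayed within the scatter, so no step beyond the scatter is expected in this assay here. The expected change is a 1.1-fold higher number from compound 1 to compound 3 (0.05 log units; within the scatter). Compound 3 is expected at 28000 nM, with an estimated range of 13000 nM to 55000 nM.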

Compound 3, half-maximal inhibitory concentration: 22200 nM
Estimate against measurement, compound 3: 1.3-fold (0.10 log units) above; measured number inside the range.
By their numbers in this assay, from the lowest: compounds 3, 1 and 2 (each within the scatter of the next, the first and the last beyond it).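

In this assay, chloro and fluoro on the benzyl group cannot be told apart, with a 1.1-fold lower number from compound 1 to compound 3 (0.05 log units; within the scatter). Chloro in place of phenyl gives the first step at this position beyond the scatter, though a modest one: a 2.2-fold lower number from compound 2 to compound 3 (0.34 log units; beyond the scatter). Nothing measured here explains either step. The compounds shown leave open whether an amine, a methoxy group or a longer chain at this position would move the number further, and whether a plain hydrogen there would change it at all.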